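This account rests on a few compounds, and the source may have more. Where it says the series, first, only, none or still open, it means among the compounds named here.

Measured compounds:
- Compound 1, `COc1cccc(C(=O)Nc2cc(-c3ccccc3)nn2-c2ccccc2)c1`, in a functional assay on cells for positive allosteric modulation of metabotropic glutamate receptor 5 (Rattus norvegicus), read by calcium flux (on this read-out lower numbers stand for an effect already at smaller amounts and higher numbers for an effect only at larger amounts of compound), compound 1 gives 102 nM.
- Compound 2, `COc1cc(OC)cc(C(=O)Nc2cc(-c3ccccc3)nn2-c2ccccc2)c1`, in this assay compound 2 gives 2040 nM.

Within the data shown here, of these two numbers, compound 2 has the higher one, and the single measured step is a 20-fold higher number from compound 1 to compound 2 (1.30 log units; beyond the scatter). Compound 3, `Cc1ccc(C(=O)Nc2cc(-c3ccccc3)nn2-c2ccccc2)cc1C`, has not yet been measured. It differs from compound 2 in one place: 3,4-dimethylphenyl in place of 3,5-dimethoxyphenyl on a carbonyl carbon.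

Among the measured compounds shown here, only one measured step bears on this change, and only in part: the step from compound 1 to compound 2 shows what one added methoxy did, and the change to compound 3 removes both methoxy groups while bringing in two methyl groups on a ring of the same size. For the loss of methoxy the measured step points toward a lower number, and its size was large. For the measured compounds named here, for the entering methyl groups no measured step exists, so their effect cannot be anchored.

Taken together, the expected step in this assay is an 8.2-fold lower number from compound 2 to compound 3 (0.91 log units; beyond the scatter), toward a lower number. For compound 3 the estimated value in this assay is 250 nM, with a range from 50 nM to 1500 nM.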

Compound 3, half-maximal effective concentration: 20 nM
Estimate against measurement, compound 3: 13-fold (1.10 log units) above; the measured number lies below the stated range.
By their numbers in this assay, from the lowest: compound 3; then compound 1; then compound 2.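

Compound 3 shows that the group on the carbonyl carbon can move the number in this assay a long way in the favourable direction, not only the unfavourable one, with a 100-fold lower number from compound 2 to compound 3 (2.01 log units; beyond the scatter) when 3,4-dimethylphenyl replaces 3,5-dimethoxyphenyl. The result also goes past the removal of the extra methoxy group: a ring with two methyl groups and no methoxy at all gives a 5.1-fold lower number from compound 1 to compound 3 (0.71 log units; beyond the scatter) in a step that lies beyond the usual scatter, so compound 3 has the lowest number of the three and compound 1 no longer marks the best this position can do. Nothing measured here explains why this exchange has such a large effect.

From the compounds shown here alone, the methyl groups and the places they occupy on the ring change together in these steps, so it remains open whether the kind of group, its place on the ring or both account for the lower number. Going by these compounds, it is also open how this position would respond to a ring carrying a chlorine atom, a nitrile or an amine.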